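Pyrazinyl in place of thiazolyl on the amide nitrogen

The compounds below may be only part of what the source reports. "The series", "measured", "known", "first", "only" and "open" are said of these compounds alone.

Compound 1 `Cc1cccc(NC(=O)c2c(O)c3cccnc3n(-c3ccccc3)c2=O)c1`: 4.5%
Compound 2 `O=C(Nc1nccs1)c1c(O)c2cccnc2n(-c2ccccc2)c1=O`: 2.5%

Both measured compounds share one core and differ only in the group on the amide-type nitrogen. In a functional assay on the whole organism for inhibition, with Rattus norvegicus as the target, read by cytopathic effect and paw edema, at a dose of 100 mg/kg by the oral route (on this read-out lower numbers stand for less inhibition and higher numbers for more inhibition at the one dose given (going by the name of the read-out)), compound 1 gives 4.5% and compound 2 gives 2.5%. For the measured compounds named here, the one measured step, a number 2 percentage points lower from compound 1 to compound 2 (within the scatter), is within the scatter, so compound 2 and compound 1 cannot be set apart on these numbers; compound 2 stands with compound 1 in a band of small inhibition.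

Compound 3 `O=C(Nc1cnccn1)c1c(O)c2cccnc2n(-c2ccccc2)c1=O` is not yet measured. The change from compound 2 to compound 3 is pyrazin-2-yl in place of 1,3-thiazol-2-yl on an amide-type nitrogen. Going by the values given here, the only step that bears on it, the exchange of one ring for another on the same amide-type nitrogen, gave a number 2 percentage points lower from compound 1 to compound 2 (within the scatter), a shift within the scatter. On that basis no step beyond the scatter is expected in this assay for compound 3, in either direction, and the expected shift is a number 0.5 percentage points higher from compound 2 to compound 3 (within the scatter).

Compound 3 is therefore estimated at 3% in this assay, with a range from -6% to 12%.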

Compound 3, a percentage reported as inhibition, in the whole organism at one dose (the size of the read-out at that dose, not a potency): 21.2%
Estimate against measurement, compound 3: 18.2 percentage points below; the measured number lies above the stated range.
By their numbers in this assay, from the lowest: compounds 2 and 1 (each within the scatter of the next); then compound 3.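

The group on the amide-type nitrogen turns out not to be indifferent in this assay: the earlier exchange of one ring for another left compounds 1 and 2 within the scatter of each other, whereas pyrazin-2-yl gives a number 18.7 percentage points higher from compound 2 to compound 3 (beyond the scatter) and also a number 16.7 percentage points higher from compound 1 to compound 3 (beyond the scatter). Among these three compounds, only the pyrazin-2-yl group sets its compound apart, and the size of the step remains modest. The change from 1,3-thiazol-2-yl to pyrazin-2-yl replaces a five-membered aromatic ring holding sulfur and nitrogen with a six-membered aromatic ring holding two nitrogens, while the counts of hydrogen-bond donors and acceptors stay the same, and nothing available here explains why this exchange moves the number.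

As far as these compounds go, it remains open whether a pyridin-2-yl or pyrimidin-2-yl group on the same nitrogen would stay with compound 3 or fall back towards compounds 1 and 2. Also open, from the compounds shown here alone, is what an amine or a carboxylic acid on the pyrazin-2-yl ring would do to the number, and how compound 3 would behave at other doses in this assay.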